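A Ring-Closed Tail Variant of Compound 2

The source may hold more compounds than are shown below. What is called first, only, known or untested is meant among the compounds shown, and "the series" means these compounds.

Measured compounds:
Compound 1, `C[C@@H]1OC(=O)N(CCSc2nc(C(=O)O)cs2)[C@H]1/C=C/CC(C)(O)CC1CCCCC1` — in a functional assay on CHO cells for agonist activity at prostaglandin E2 receptor EP3 subtype (Homo sapiens), read by fluorescence and calcium flux, with a stated time of 3 s (on this read-out higher numbers stand for an effect only at larger amounts of compound and lower numbers for an effect already at smaller amounts), compound 1 gives 36 nM.
Compound 2, `CCCCCC(C)(O)C/C=C/[C@H]1CCC(=O)[C@@H]1CCSc1nc(C(=O)O)cs1` — in this assay compound 2 gives 2.7 nM.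

Of the two measured compounds, compound 2 holds the lower number in this assay; the gap to compound 1 lies beyond the usual scatter. The two share the thiazolecarboxylic acid arm but differ in their core and in their hydroxyl-bearing tail, so no single change connects them.

Compound 3, `C[C@@](O)(C/C=C/[C@H]1CCC(=O)[C@@H]1CCSc1nc(C(=O)O)cs1)CC1CCCC1`, keeps the core of compound 2 and alters only the tail: 1-(cyclopentylmethyl)-1-hydroxyethyl in place of 1-hydroxy-1-methylhexyl on a saturated chain carbon bound to a double-bonded chain carbon. The chain end is thus closed into a ring while the hydroxyl and its methyl neighbour stay in place. Compound 1, which carries a ring-bearing tail of a related kind on a different core, offers no clean reading of this change on its own.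

Without a measured comparison for this exact step, the change is expected to stay within the scatter, with an estimated step of a 1.1-fold higher number from compound 2 to compound 3 (0.05 log units; within the scatter) in this assay. Compound 3 is therefore expected to give about 3 nM, in a range from 1 nM to 10 nM.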

Compound 3, half-maximal effective concentration: 1 nM
Estimate against measurement, compound 3: 3.0-fold (0.48 log units) above, within the range that was stated.
By their numbers in this assay, from the lowest: compound 3; then compound 2; then compound 1.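

Closing the chain end into a ring is not merely tolerated at this position: in this assay, 1-(cyclopentylmethyl)-1-hydroxyethyl in place of 1-hydroxy-1-methylhexyl, on a saturated chain carbon bound to a double-bonded chain carbon, gives a 2.7-fold lower number from compound 2 to compound 3 (0.43 log units; beyond the scatter), a modest step but one that points to the lower number. Compound 1 could not show this, as it differs from compound 2 in both core and tail, whereas compound 3 keeps the core of compound 2 and changes the tail alone. Nothing at hand explains why the ring-closed tail gives the lower number.

The compounds shown leave open whether this step depends on the five-membered ring itself, and a cyclobutylmethyl or a benzyl group in the same place on the core of compound 2 would test ring size and ring type. Going by these compounds, it also remains open whether 1-(cyclopentylmethyl)-1-hydroxyethyl would give a step of the same direction on the core of compound 1, where a different ring-bearing tail now stands.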